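Working notes: from compound 1 to compound 4

A few compounds are considered here, and "the series" means these few. Any claim that something is new, unique, unknown or untested is made for them only; others in the source may bear on it.

Measured in a functional assay on MGC-803 cells (Homo sapiens) for antiproliferative activity, read by MTT assay, with a stated time of 72 h; on this read-out lower numbers stand for stronger inhibition and higher numbers for weaker inhibition:
compound 1 (`CCCSc1nc(N/N=C/c2ccc(C)cc2)c2nnn(Cc3ccccc3)c2n1`): > 64000 nM (a limit, not a number)
compound 2 (`C/C(=N\Nc1nc(SCc2ccccc2)nc2c1nnn2Cc1ccccc1)c1ccccc1O`): 850 nM
compound 3 (`C#CCSc1nc(N/N=C/c2cc(OC)c(OC)c(OC)c2)c2nnn(Cc3ccccc3)c2n1`): 4670 nM

Compound 1 sits at the limit of > 64000 nM in this assay, at which 1 of the 3 values shown sits, and so has only a limit, with no number of its own. Compound 4 (`CCCSc1nc(N/N=C/c2ccc(N(C)C)cc2)c2nnn(Cc3ccccc3)c2n1`) is compound 1 with one change: dimethylamino in place of methyl on an aromatic carbon, para to a large group (dimethylamino in place of methyl on an aromatic carbon). Within the data shown here, no measured pair in this set isolates that change, so its size cannot be read directly from the data.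

In this assay compound 2 gives 850 nM and compound 3 gives 4670 nM and both differ from compound 1 in more than one place. Among the measured compounds shown here, those two values show only that compounds sharing this core can give real numbers in this read-out. On that basis the direction expected for the change is towards stronger inhibition, with a moderate size and a real chance that compound 4 also returns only a limit. The expected size is an at least 2.5-fold lower number from compound 1 to compound 4 (0.40 log units; beyond the scatter) (estimated, and uncertain). The estimate for compound 4 is 25000 nM with an expected range from 4000 nM to 64000 nM in this read-out.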

Compound 4, half-maximal inhibitory concentration: 13100 nM
Beside the measured number, compound 4's estimate is 1.9-fold (0.28 log units) above it; the measured number falls inside the stated range.
By their numbers in this assay, from the lowest: compound 2; then compound 3; then compound 4. At a limit, above all of these: compound 1.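

In this assay, among these compounds, the change from 4-methylphenyl to 4-(dimethylamino)phenyl is the only single-place change that can be read, and it gives an at least 4.8-fold lower number from compound 1 to compound 4 (0.68 log units; beyond the scatter). This shows that the position, on an aromatic carbon para to a large group, matters for the read-out: with the rest of compound 1 unchanged, dimethylamino in place of methyl is enough to give compound 4 a real number. The step remains a bound and not a size because compound 1 has only a limit, with no number of its own: the limit of > 64000 nM in this assay, at which 1 of the 4 values shown sits.

From the compounds shown here alone, whether a primary amine, a morpholine ring or a carboxylic acid at this place would give a lower or a higher number than compound 4 remains open, as does whether dimethylamino itself is needed or a second group of similar size would serve. Also open, going by these compounds, is whether the same change would hold with a different chain on the sulfur, since compound 2 and compound 3 differ from compound 4 in more than one place and give no reading of it.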